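This account rests on a few compounds, and the source may have more. Where it says the series, first, only, none or still open, it means among the compounds named here.

Measured so far:
compound 1 `COc1cccc(-c2ccc(C(=O)N(Cc3cccc(OCCCCCC(=O)O)c3)C(C)C)cc2)c1` gives > 20900 nM in an ADME assay on HEK293 cells (Homo sapiens) for cytotoxicity, read by CellTiter-Glo and resazurin assay, with a stated time of 72 h; a lower number here means that less compound is needed, a higher number that more compound is needed for the effect; this is a limit of the assay, not a number.
compound 2 `COc1cc(F)cc(-c2ccc(C(=O)N(Cc3cccc(OCCCCCC(=O)O)c3)C(C)C)cc2)c1` gives > 26000 nM in this assay; this too is a limit.

Compound 2 thus stands only at a limit, with no numerical position beyond it. Among the measured compounds shown here, the single measured step, a step that the two limits leave unreadable from compound 1 to compound 2, cannot be read because the limit of > 20900 nM in this assay, at which 1 of the 2 values shown sits, and the limit of > 26000 nM in this assay, at which 1 of the 2 values shown sits, both sit at limits. No size of change for the fluoro in place of hydrogen is therefore available.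

Compound 3 `CC(C)N(Cc1cccc(OCCCCCC(=O)O)c1)C(=O)c1ccc(-c2cccc([N+](=O)[O-])c2)cc1` carries 3-nitrophenyl in place of 3-fluoro-5-methoxyphenyl on an aromatic carbon. For the measured compounds named here, the one measured step bears on this change only insofar as both of its ends lie at limits, so it gives no size and no direction to carry over; what it does show is that neither compound 1 nor compound 2 reached a measurable effect. Compound 3 is accordingly expected to behave likewise in this assay, most likely again as a limit rather than a number. For compound 3 the estimate is 30000 nM, with a range of 10000 nM to 100000 nM. The implied step that the limit leaves unreadable from compound 2 to compound 3 is an expectation of no change beyond the scatter.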

Compound 3, half-maximal effective concentration: > 26000 nM
Compound 3: a limit, no number (the forecaster's own chance of this, stated with the estimate: 80%); the middle value does not contradict the limit.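

In this assay compound 3 gives > 26000 nM, which is a limit and not a number. The steps from compound 1 and compound 2 to compound 3 cannot be read. The compounds shown leave open where any of the three would reach a half-maximal effect.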